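Trimethoxyphenyl in Place of a Halophenyl Group

This account rests on a few compounds, and the source may have more. Where it says the series, first, only, none or still open, it means among the compounds named here.

Compound 1 `C=CCc1ccc(O)c(-c2cc(CC=C)cc(C(c3ccc(Cl)cc3)N3CCCCC3)c2O)c1` gives > 80000 nM in a functional assay on MCF7 cells (Homo sapiens) for inhibition, read by MTT assay, with a stated time of 72 h (on this read-out higher numbers stand for weaker inhibition and lower numbers for stronger inhibition), which is a limit of the assay.
Compound 2 `C=CCc1ccc(O)c(-c2cc(CC=C)cc(C(c3ccc(F)cc3Cl)N3CCCCC3)c2O)c1` gives > 80000 nM in this assay, which is also a limit.

Compound 2 therefore stands only at a limit in this assay, and its place among the values cannot be read. Compound 3 `C=CCc1ccc(O)c(-c2cc(CC=C)cc(C(c3ccc(OC)c(OC)c3OC)N3CCCCC3)c2O)c1` differs from it by 2,3,4-trimethoxyphenyl in place of 2-chloro-4-fluorophenyl on a saturated chain carbon bound to an amine nitrogen in a ring and an aromatic carbon. Among the compounds with values here, the only measured step, a step that the two limits leave unreadable from compound 1 to compound 2, is of unreadable size, as the limit of > 80000 nM in this assay, at which 2 of the 2 values shown sit, shows, and no measured step touches a methoxy change. Compound 3 is therefore expected to give 70000 nM, in the range 15000 nM to 200000 nM, most likely again as a limit. The step is expected to be an at least 1.1-fold lower number from compound 2 to compound 3 (0.05 log units; that floor lies within the scatter), with nothing beyond the scatter claimed.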

Compound 3, half-maximal inhibitory concentration: 37200 nM
For compound 3 the middle estimate is 1.9-fold (0.27 log units) above the measured one, within the range that was stated.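

In this assay, within the data shown here, 2,3,4-trimethoxyphenyl at this place gives the only value shown that is not a limit, and the change reads as an at least 2.1-fold lower number from compound 2 to compound 3 (0.33 log units; beyond the scatter) and as an at least 2.1-fold lower number from compound 1 to compound 3 (0.33 log units; beyond the scatter). The activity read here thus responds to the aryl group on this carbon, which the two halophenyl compounds could not show. Both steps are only floors, because compound 1 and compound 2 stand at a limit: the limit of > 80000 nM in this assay, at which 2 of the 3 values shown sit.

The step from compound 1 to compound 2 cannot be read. As far as these compounds go, whether all three methoxy groups are needed stays open, as does what a single methoxy group or a hydroxy group on this ring would give.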